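Swapping a Side Ring at the Low End

The compounds below may be only part of what the source reports. "The series", "measured", "known", "first", "only" and "open" are said of these compounds alone.

Of the compounds shown here, two have so far been measured in a physicochemical assay for acid dissociation. Compound 1 `CC(C)c1cc(Nc2cccc(Cl)c2)ncc1C(=O)NC1CCOCC1` gives 6.02. Compound 2 `NC(=O)c1ccc(CNC(=O)c2cnc(Nc3cccc(Cl)c3)cc2C(F)(F)F)cc1` gives 2.63, the lower of the two numbers, and the gap between them lies well beyond the scatter of repeat measurements. These two compounds differ in more than one place, so their gap does not tie the number to any single group.

Compound 3 `O=C(NCC1CCCCC1)c1cnc(Nc2cccc(Cl)c2)cc1C(F)(F)F` has not yet been measured. It differs from compound 2 in one place: cyclohexyl stands in place of 4-carbamoylphenyl on a saturated chain carbon bound to an amide-type nitrogen (cyclohexyl in place of 4-carbamoylphenyl on a saturated chain carbon bound to an amide-type nitrogen). The shared core stays as it is, so the closest guide is compound 2 at 2.63. Among the compounds with values here, no measured pair shows directly what this kind of swap does. In this assay the expected change is therefore small and slightly upward, within the scatter: a number 0.07 log units higher from compound 2 to compound 3 (within the scatter). For compound 3 the estimated value is 2.7, with an expected range of 2.3 to 3.2.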

Compound 3, acid dissociation constant: 2.63
The estimate for compound 3 lay 0.07 log units above the measured number; measured number inside the range.
By their numbers in this assay, from the lowest: compounds 2 and 3 (each within the scatter of the next); then compound 1.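

Within the data shown here, this is the first pair in the set that differs in one place only, so it gives the first direct reading of this position in this assay: cyclohexyl in place of 4-carbamoylphenyl, on a saturated chain carbon bound to an amide-type nitrogen, gives no change at the digits printed from compound 2 to compound 3 (within the scatter). The change is not a minor one on paper, since the aromatic ring gives way to a non-aromatic ring and the hydrogen-bond donor and acceptor of the leaving group are gone, yet this read-out does not register it. Nothing available here explains why the number holds steady across this swap.

What an amine or a carboxylic acid would do in place of cyclohexyl at this same spot remains open, since both side groups shown here carry neither, and one pair cannot say how far the flat result extends to other kinds of group. Going by these compounds, it also remains open whether the same swap would give the same result on the core of compound 1, where the number stands at 6.02.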